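Isothiocyanate linker length on a pyrrolopyrimidine amide series

The source may report more compounds than this note shows. Statements on the series, on what has been measured and on what is new or still open speak of the compounds shown alone.

Measured so far:
compound 1 `CN(C)C(=O)c1cc2cnc(Nc3ccc(C(=O)NCCCCCCN=C=S)cc3)nc2n1C1CCCC1` 85%
compound 2 `CN(C)C(=O)c1cc2cnc(Nc3ccc(C(=O)NCCCCCCCN=C=S)cc3)nc2n1C1CCCC1` 107%
compound 3 `CN(C)C(=O)c1cc2cnc(Nc3ccc(C(=O)NCCCN=C=S)cc3O)nc2n1C1CCCC1` 24.2%

In a functional assay on NCI-H1299 cells (Homo sapiens) for inhibition, read by CCK-8 assay, with a stated time of 72 h, tested at 10 uM (a higher number here means a stronger effect of the compound at the concentration tested, a lower number a weaker effect), compound 1 gives 85%. Compound 2 gives 107%, and the step of a number 22 percentage points higher from compound 1 to compound 2 (beyond the scatter) comes with the change (a group of 4 heavy atoms (2 carbon, 1 nitrogen, 1 sulfur; no ring) in place of a group of 3 heavy atoms (1 carbon, 1 nitrogen, 1 sulfur; no ring), on a saturated chain carbon, six bonds along the chain from an amide-type nitrogen). Compound 3 gives 24.2%, the lowest of the three; the difference between the core of compound 3 and the core of compound 1 is not broken down here.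

Compound 4 `CN(C)C(=O)c1cc2cnc(Nc3ccc(C(=O)NCCCCN=C=S)cc3O)nc2n1C1CCCC1` is not yet measured. It differs from compound 3 by a group of 4 heavy atoms (2 carbon, 1 nitrogen, 1 sulfur; no ring) in place of a group of 3 heavy atoms (1 carbon, 1 nitrogen, 1 sulfur; no ring), on a saturated chain carbon, three bonds along the chain from an amide-type nitrogen. This is the same kind of change as from compound 1 to compound 2, but the place differs: there the group sat six bonds along the chain from the amide-type nitrogen, here three bonds. Going by the values given here, a step of a number 15.8 percentage points higher from compound 3 to compound 4 (beyond the scatter) is expected, resting on the single earlier step of a number 22 percentage points higher from compound 1 to compound 2 (beyond the scatter), discounted because compound 3 gives 24.2% on a different core. Compound 4 is estimated at 40%, between 18% and 65%.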

Compound 4, a percentage reported as inhibition, at one concentration (the size of the read-out at that concentration, not a potency): 51.8%
Compound 4: the middle estimate sits 11.8 percentage points below what was measured; the range from low to high includes it.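

In this assay, lengthening the isothiocyanate chain also raises the read-out on the core of compound 3, a number 27.6 percentage points higher from compound 3 to compound 4 (beyond the scatter), and this step does not differ from the earlier one: the same change on two cores in this assay, a number 22 percentage points higher (beyond the scatter) from compound 1 to compound 2 and a number 27.6 percentage points higher (beyond the scatter) from compound 3 to compound 4, 5.6 percentage points apart, within the scatter of two such steps. The change therefore carries over between these two cores, although the place of the change along the chain also differs between the two pairs. This rests on one pair per core and says nothing about other cores, nor does it separate the core difference itself, as compound 1 and compound 3 differ in more than one place.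

As far as these compounds go, whether a longer chain on the core of compound 3 adds further to the effect remains open. So does whether an amine or a carboxylic acid in place of the isothiocyanate retains it.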